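Removing an Ester From Compound 2: Expectation for Compound 3

The source may hold more compounds than are shown below. What is called first, only, known or untested is meant among the compounds shown, and "the series" means these compounds.

Measured so far:
- Compound 1, `CC(=O)O[C@@H](CC1=C(O)C(=O)OC1)[C@]1(C)[C@H]2CCC=C(C)[C@]2(C)[C@@H](OC(=O)c2cccnc2)[C@H](O)[C@]1(C)O`: 18.5%
- Compound 2, `CC(=O)OC(C(=O)O[C@H]1[C@H](OC(=O)c2cccnc2)[C@@]2(C)C(C)=CCC[C@@H]2[C@@](C)(CCC2=C(O)C(=O)OC2)[C@@]1(C)O)C(C)C`: 37.6%

Both compounds were tested in a functional assay on MCF7 cells (Homo sapiens) for inhibition, read by MTT assay, with a stated time of 48 h, tested at 50 uM; a higher number here means more inhibition at the concentration tested (going by the name of the read-out), a lower number less inhibition. Compound 2 gives 37.6%, the higher of the two numbers, and compound 1 with 18.5% sits a long way beneath it, a gap that lies beyond the scatter of repeated measurements. Going by the values given here, no step between compounds that differ in a single place has been measured, so nothing is yet known about how one small change shifts the read-out.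

Compound 3, `CC1=CCC[C@H]2[C@@]1(C)[C@@H](OC(=O)c1cccnc1)[C@H](O)[C@](C)(O)[C@]2(C)CCC1=C(O)C(=O)OC1`, takes one such step from compound 2. The change is hydrogen in place of (1-acetoxy-2-methylpropyl)carbonyl on an oxygen on a saturated carbon. The (1-acetoxy-2-methylpropyl)carbonyl group, with its seven carbon and three oxygen atoms, simply disappears, leaving a hydroxy in its place.

Among the compounds with values here, with no measured step to lean on, the expectation rests on the two values alone. Compound 3 is expected to fall below compound 2, with a step of a number 15.6 percentage points lower from compound 2 to compound 3 (beyond the scatter) that goes beyond the scatter. Compound 3 is thus estimated at 22%, between 5% and 42%.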

Compound 3, a percentage reported as inhibition, at one concentration (the size of the read-out at that concentration, not a potency): 28.5%
Beside the measured number, compound 3's estimate is 6.5 percentage points below it; the measured number falls inside the stated range.
By their numbers in this assay, from the lowest: compounds 1, 3 and 2 (each within the scatter of the next, the first and the last beyond it).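

In this assay, taking the (1-acetoxy-2-methylpropyl)carbonyl group off the oxygen on a saturated carbon and leaving a hydroxy gives a number 9.1 percentage points lower from compound 2 to compound 3 (within the scatter), the first single-place change seen at this position, and it shows that this whole ester can go without a shift that stands clear of ordinary repeat variation. The second step, hydrogen in place of acetoxy on a saturated chain carbon bound to a saturated chain carbon and a saturated ring carbon, gives a number 10 percentage points higher from compound 1 to compound 3 (within the scatter), so at this other place too, the assay cannot separate the compounds with and without the group. Nothing measured here offers an explanation for either result.

Going by these compounds, what stays open is whether a different group on that same oxygen, such as a benzoyl, a longer chain or a chain carrying an amine, would move the read-out beyond the scatter. Each number also comes from a single concentration, so these steps say nothing about how potency changes across the compounds.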